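This account rests on a few compounds, and the source may have more. Where it says the series, first, only, none or still open, it means among the compounds named here.

Measured in a functional assay on A549 cells (Homo sapiens) for cytotoxicity, read by MTT assay, with a stated time of 72 h; a lower number here means a stronger inhibitor, a higher number a weaker inhibitor:
- compound 1 `O=C(/C=C/c1cccc(Cl)c1Cl)Nc1cc2c(Nc3ccc(F)c(Cl)c3)ncnc2cc1O[C@H]1CCOC1`: 23200 nM
- compound 2 `COc1ccc(/C=C/C(=O)Nc2cc3c(Nc4ccc(F)c(Cl)c4)ncnc3cc2O[C@H]2CCOC2)c(OC)c1`: 9350 nM
- compound 3 `N#Cc1ccc(/C=C/C(=O)Nc2cc3c(Nc4ccc(F)c(Cl)c4)ncnc3cc2O[C@H]2CCOC2)cc1`: "not active" (no number reported)

Compound 3 has no place on the numeric scale. In this assay, going by the values given here, compound 3 is recorded as "not active" (no number reported), without a number, so no step in size can be stated between it and any other compound.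

The next compound is compound 4 `O=C(/C=C/c1ccccc1[N+](=O)[O-])Nc1cc2c(Nc3ccc(F)c(Cl)c3)ncnc2cc1O[C@H]1CCOC1`, and the change from compound 3 is 2-nitrophenyl in place of 4-cyanophenyl on a double-bonded chain carbon bound to a double-bonded chain carbon. In words, 2-nitrophenyl stands in place of 4-cyanophenyl, on a double-bonded chain carbon bound to a double-bonded chain carbon. The three measured compounds also differ from one another at this place.

Among the compounds with values here, only one measured step bears on the change: a 2.5-fold lower number from compound 1 to compound 2 (0.39 log units; beyond the scatter). It involves neither of the groups exchanged here, so it gives only a rough size for changes at this place. Compound 3 shows that such a change can also end without a number. If compound 4 gives a number, it is expected to lie in the same weak region as compound 1 and compound 2, and no finer direction can be drawn from these data. A result without a number remains a real possibility.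

For compound 4 the estimated value is 18000 nM, with an expected range of 6000 nM to 50000 nM.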

Compound 4, half-maximal inhibitory concentration: 8820 nM
Estimate against measurement, compound 4: 2.0-fold (0.31 log units) above; low and high end bracket the measured number.
By their numbers in this assay, from the lowest: compounds 4 and 2 (each within the scatter of the next); then compound 1.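

In this assay, compound 4 gives 8820 nM, so a record without a number is not general for single substituted phenyl groups at this place, although the step from compound 3 to compound 4 cannot be read as a size. Among the numbered compounds, 2-nitrophenyl and 2,4-dimethoxyphenyl do not separate, with a 1.1-fold lower number from compound 2 to compound 4 (0.03 log units; within the scatter), while 2-nitrophenyl in place of 2,3-dichlorophenyl gives a 2.6-fold lower number from compound 1 to compound 4 (0.42 log units; beyond the scatter), which leaves compound 1 as the only numbered compound set apart from the others. Nothing available explains why these groups give these results or why compound 3 has no number.

The data leave open whether the missing number of compound 3 goes with the nitrile itself or with the 4-cyanophenyl group as a whole, since compound 4 changes both the group and its name-given placement on the ring. Also open, on these data alone, is whether an amine, a carboxylic acid or a saturated alkyl chain in place of the phenyl ring would give a number outside the narrow range seen so far, or no number at all.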